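The source may hold more compounds than are shown below. What is called first, only, known or untested is meant among the compounds shown, and "the series" means these compounds.

Of the compounds shown here, two have been measured in an assay on membranes from liver for displacement of a labelled ligand from Sigma intracellular receptor 2 (Rattus norvegicus), read by scintillation counting, with a stated time of 120 min, in the presence of a further agent that is not named here; on this read-out lower numbers stand for stronger inhibition and higher numbers for weaker inhibition. Compound 1, with the structure `c1ccc(CCCCNC2CCc3ccsc3CC2)cc1`, gives 5.7 nM in this assay. Compound 2, with the structure `CN(CCCc1ccccc1)C1CCc2ccsc2CC1`, gives 13 nM in this assay, which is the higher of the two numbers; the gap to compound 1 lies beyond the usual scatter of repeated measurements, so compound 2 is the weaker of the pair.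

Compound 3, with the structure `CN(CCCCc1ccccc1)C1CCc2ccsc2CC1`, has not yet been measured in this assay. It differs from compound 2 in one place: benzyl in place of phenyl on a saturated chain carbon, three bonds along the chain from an amine nitrogen. Among the measured compounds shown here, no measured pair in this set isolates that particular change, so nothing is known directly about what it does here.

What can be said is that compound 1 gives 5.7 nM in this assay while compound 2 gives 13 nM, and that compound 3 carries the longer chain. On that basis a modest lowering of the number is expected, so that the step of a 1.6-fold lower number from compound 2 to compound 3 (0.21 log units; within the scatter) is estimated to fall near the edge of the scatter rather than far beyond it. Compound 3 is therefore expected to give about 8 nM in this assay, with a range from 3 nM to 20 nM.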

Compound 3, inhibition constant: 12 nM
Beside the measured number, compound 3's estimate is 1.5-fold (0.18 log units) below it, and the stated range covers the measured number.
By their numbers in this assay, from the lowest: compound 1; then compounds 3 and 2 (each within the scatter of the next).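

In this assay, benzyl in place of phenyl on a saturated chain carbon, three bonds along the chain from an amine nitrogen, gives a 1.1-fold lower number from compound 2 to compound 3 (0.03 log units; within the scatter); so with the methyl on the amine nitrogen in place, this added chain carbon leaves no change that can be told from the scatter. Methyl in place of hydrogen on an amine nitrogen, at the same chain length, gives a 2.1-fold higher number from compound 1 to compound 3 (0.32 log units; beyond the scatter), which isolates that change for the first time and shows that, among these three compounds, the gap beyond the scatter goes with the methyl and not with the chain length. Nothing measured here gives a reason for either step.

Going by these compounds, it remains open whether the methyl step would be of similar size on the shorter chain of compound 2, which would take the compound with hydrogen in place of that methyl. The compounds shown also leave open whether a longer chain than that of compound 3, or an ethyl group on the amine nitrogen, would shift the number beyond the scatter.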